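Branching the nitrogen substituent in a vitamin D receptor antagonist series

The compounds below may be only part of what the source reports. "The series", "measured", "known", "first", "only" and "open" are said of these compounds alone.

Measured compounds:
Compound 1, `CCCn1c(-c2ccc(OCc3c(-c4c(Cl)cccc4Cl)noc3C(C)C)cc2)nc2ccc(C(=O)O)cc21`: 1400 nM
Compound 2, `CC(C)c1onc(-c2c(Cl)cccc2Cl)c1COc1ccc(-c2nc3ccc(C(=O)O)cc3n2CC2CC2)cc1`: 2650 nM

Compound 1 `CCCn1c(-c2ccc(OCc3c(-c4c(Cl)cccc4Cl)noc3C(C)C)cc2)nc2ccc(C(=O)O)cc21` and compound 2 `CC(C)c1onc(-c2c(Cl)cccc2Cl)c1COc1ccc(-c2nc3ccc(C(=O)O)cc3n2CC2CC2)cc1` share one core and differ only in the group on the saturated chain carbon bound to the aromatic nitrogen. In an assay on HEK-293T cells for antagonist activity at vitamin D3 receptor (Homo sapiens), read by a luciferase reporter, with a stated time of 24 h (on this read-out lower numbers stand for stronger inhibition and higher numbers for weaker inhibition), compound 1 gives 1400 nM and compound 2 gives 2650 nM. Among the compounds with values here, the one measured step, a 1.9-fold higher number from compound 1 to compound 2 (0.28 log units; within the scatter), leaves compound 2 with the higher of the two numbers, though the two stand within the scatter of each other.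

Compound 3 `CC(C)Cn1c(-c2ccc(OCc3c(-c4c(Cl)cccc4Cl)noc3C(C)C)cc2)nc2ccc(C(=O)O)cc21` carries the change (isopropyl in place of cyclopropyl on a saturated chain carbon bound to an aromatic nitrogen), so cyclopropylmethyl becomes isobutyl. Within the data shown here, only the step from compound 1 to compound 2 bears on it, and that step was small. The step expected for compound 3 is therefore a 1.2-fold lower number from compound 2 to compound 3 (0.08 log units; within the scatter), with no direction beyond the scatter. Compound 3 is estimated at 2200 nM in this assay, within 800 nM to 6000 nM.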

Compound 3, half-maximal inhibitory concentration: 1180 nM
Compound 3: middle estimate off by 1.9-fold (0.27 log units), on the high side, within the range that was stated.
By their numbers in this assay, from the lowest: compounds 3, 1 and 2 (each within the scatter of the next, the first and the last beyond it).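

Cyclopropyl and isopropyl have the same count of heavy atoms, yet in this assay the change from cyclopropylmethyl to isobutyl gives the first step at this position that lies beyond the scatter, though only a modest one (a 2.2-fold lower number from compound 2 to compound 3 (0.35 log units; beyond the scatter)). Methyl in place of hydrogen on the chain gives no such separation (a 1.2-fold lower number from compound 1 to compound 3 (0.07 log units; within the scatter)), so compound 1 stays within the scatter of both other compounds and only compound 2 and compound 3 stand apart. No measurement shown accounts for the difference between the ring and the open chain.

The compounds shown leave open whether a longer chain, such as hexyl, or a chain ending in an amine would move the number further at this position. They also leave open whether the step between compound 2 and compound 3 would recur on another core.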